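The compounds below may be only part of what the source reports. "The series", "measured", "known", "first", "only" and "open" are said of these compounds alone.

Of the compounds shown here, three with a shared core have been tested in a functional assay on the whole organism (strain albino) with Mus musculus as the target, in the maximal electroshock model, with a stated time of 4 h; on this read-out higher numbers stand for an effect only at larger amounts of compound and lower numbers for an effect already at smaller amounts. Compound 1 `COc1ccccc1Nc1nnc(Nc2nc(-c3ccc(Cl)cc3)cs2)s1` gives 300 mg/kg, and compound 2 `COc1ccccc1Nc1nnc(Nc2nc(-c3ccc([N+](=O)[O-])cc3)cs2)s1` gives 300 mg/kg; the step of no change at the digits printed from compound 1 to compound 2 (within the scatter) shows that swapping nitro for chloro on an aromatic carbon made no difference. Compound 3 `Cc1ccc(Nc2nnc(Nc3nc(-c4ccccc4)cs3)s2)cc1` stands lowest of the three with 100 mg/kg, a step beyond the scatter from both compound 1 and compound 2.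

Compound 4 `COc1ccccc1Nc1nnc(Nc2nc(-c3ccccc3)cs2)s1` is reached from compound 3 by the change (2-methoxyphenyl in place of 4-methylphenyl on a nitrogen on an aromatic ring). Within the data shown here, no measured step covers this exact change, so the only guide is that compound 1 and compound 2, which both carry the 2-methoxyphenyl group that enters here, each gave the same higher number, while compound 3 with 4-methylphenyl gave the lower one. On that basis a step upward, beyond the scatter, is expected for a 3.0-fold higher number from compound 3 to compound 4 (0.48 log units; beyond the scatter). Compound 4 is therefore estimated at 300 mg/kg, within a range of 100 mg/kg to 600 mg/kg.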

Compound 4, minimum effective dose: 300 mg/kg
Beside the measured number, compound 4's estimate shows no gap at the digits printed; the measured number falls inside the stated range.
By their numbers in this assay, from the lowest: compound 3; then compounds 1, 2 and 4 (each within the scatter of the next).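

Seen on its own, with the rest of the molecule held the same, putting 2-methoxyphenyl in place of 4-methylphenyl on the nitrogen gives a 3.0-fold higher number from compound 3 to compound 4 (0.48 log units; beyond the scatter) in this assay, so this position does affect the dose needed. With 2-methoxyphenyl in place, the aromatic carbon that carried chloro or nitro can instead carry hydrogen, giving no change at the digits printed from compound 1 to compound 4 (within the scatter) and no change at the digits printed from compound 2 to compound 4 (within the scatter), so these three groups cannot be told apart on that carbon. Nothing here gives a measured explanation for the step at the nitrogen.

As far as these compounds go, it remains open whether chloro or nitro would also leave the number unchanged with 4-methylphenyl on the nitrogen, since only compound 3 carries that group. Also open, from the compounds shown here alone, is what an unsubstituted phenyl on that nitrogen, or an amine on that aromatic carbon, would give.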